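A few compounds are considered here, and "the series" means these few. Any claim that something is new, unique, unknown or untested is made for them only; others in the source may bear on it.

In a functional assay on A549 cells (Homo sapiens) for inhibition, read by colorimetric assay and MTT assay, with a stated time of 72 h (a higher number here means a weaker inhibitor, a lower number a stronger inhibitor), compound 1 `C=CCCCCOc1ccccc1-c1cnc(OCCC=C)n1C` gives 9000 nM, while compound 2 `C=CCCCCOc1ccc(C)cc1-c1cnc(OCCC=C)n1C` gives 59000 nM, the higher of the two numbers. Compound 3 `C=CCCCCOc1ccc(OC)cc1-c1cnc(OCCC=C)n1C` has methoxy in place of methyl on an aromatic carbon, para to a (hex-5-en-1-yl)oxy group: methoxy in place of methyl on an aromatic carbon. Among the compounds with values here, only one measured step bears on this change: a 6.6-fold higher number from compound 1 to compound 2 (0.82 log units; beyond the scatter), a modest step beyond the scatter, from methyl in place of hydrogen at the same place. Within the data shown here, no methoxy compound has been measured, so only a modest step is expected in this assay, leaning towards a lower number. The estimated step is a 2.4-fold lower number from compound 2 to compound 3 (0.37 log units; beyond the scatter). Compound 3 is estimated at 25000 nM, with an expected range of 7000 nM to 80000 nM.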

Compound 3, half-maximal inhibitory concentration: 43000 nM
The estimate for compound 3 lay 1.7-fold (0.24 log units) below the measured number; the measured number falls inside the stated range.
By their numbers in this assay, from the lowest: compound 1; then compounds 3 and 2 (each within the scatter of the next).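

In this assay, methoxy and methyl at this place, para to the (hex-5-en-1-yl)oxy group, cannot be told apart (a 1.4-fold lower number from compound 2 to compound 3 (0.14 log units; within the scatter)). Methoxy, like methyl, still stands apart from hydrogen (a 4.8-fold higher number from compound 1 to compound 3 (0.68 log units; beyond the scatter)), so both groups shown at this place go with a higher number than hydrogen. No supporting measurement offers any explanation for this.

From the compounds shown here alone, whether this holds for other groups at this place, such as fluorine, an amine or a carboxylic acid, remains open. So does whether a longer alkoxy chain than methoxy would behave in the same way.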